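The source may hold more compounds than are shown below. What is called first, only, known or untested is meant among the compounds shown, and "the series" means these compounds.

In an ADME assay on WI-38 cells (Homo sapiens) for inhibition, read by MTT assay, with a stated time of 72 h (a lower number here means a stronger inhibitor, a higher number a weaker inhibitor), compound 1 `O=C(OC1(C(=O)Nc2ccc([N+](=O)[O-])cc2)CCCCC1)c1ccc(Cl)cc1` gives 355 nM. Its nearest neighbour is compound 2 `O=C(OC1(C(=O)Nc2ccc([N+](=O)[O-])cc2)CCCCC1)c1ccc(Br)cc1`, which gives 523 nM; the step of a 1.5-fold higher number from compound 1 to compound 2 (0.17 log units; within the scatter) lies within the scatter. Among the compounds with values here, compound 3 `O=C(/C=C/c1ccccc1)OC1(C(=O)Nc2ccc([N+](=O)[O-])cc2)CCCCC1`, with 2-phenylethenyl on the carbonyl carbon, gives 41 nM, and the step of an 8.7-fold lower number from compound 1 to compound 3 (0.94 log units; beyond the scatter) is the largest movement among the three, so compound 1 stands second highest of the three numbers measured so far.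

Compound 4 `O=COC1(C(=O)Nc2ccc([N+](=O)[O-])cc2)CCCCC1` differs from compound 1 by hydrogen in place of 4-chlorophenyl on a carbonyl carbon. Within the data shown here, no measured step removes the aryl group from this carbonyl carbon altogether; the only steps that touch the same place are the halogen swap, a 1.5-fold higher number from compound 1 to compound 2 (0.17 log units; within the scatter), which stayed within the scatter, and the exchange of 4-chlorophenyl for 2-phenylethenyl, an 8.7-fold lower number from compound 1 to compound 3 (0.94 log units; beyond the scatter), which moved the number by a modest amount. What both steps show is that the group on this carbonyl carbon can change the number beyond the scatter. Taking the group away entirely is therefore expected to move the number in this assay, and in the absence of any step showing a gain from a smaller group, the expected direction is towards a higher number, with the step of a 4.2-fold higher number from compound 1 to compound 4 (0.63 log units; beyond the scatter). Compound 4 is thus estimated at 1500 nM, within a range from 400 nM to 6000 nM.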

Compound 4, half-maximal inhibitory concentration: 46.3 nM
Compound 4: the middle estimate sits 32-fold (1.51 log units) above what was measured, outside the stated range (below it).
By their numbers in this assay, from the lowest: compounds 3 and 4 (each within the scatter of the next); then compounds 1 and 2 (each within the scatter of the next).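

In this assay, the aryl group on this carbonyl carbon proves dispensable: hydrogen in place of 4-chlorophenyl gives a 7.7-fold lower number from compound 1 to compound 4 (0.88 log units; beyond the scatter), and hydrogen in place of 4-bromophenyl gives an 11-fold lower number from compound 2 to compound 4 (1.05 log units; beyond the scatter), so the smallest possible group falls on the side of the lower numbers. The step of a 1.1-fold higher number from compound 3 to compound 4 (0.05 log units; within the scatter) places hydrogen level with 2-phenylethenyl, which means that among these four compounds a low number does not depend on the size of the group, and that only the two halogen-bearing phenyl groups stand apart, on the high side. The data shown offer no measurement that accounts for this result.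

On these data alone, what a plain phenyl group would give on this carbonyl carbon stays open, and with it the question of whether the higher numbers go with the halogen or with an aromatic ring set directly on the carbonyl carbon. Also open, as far as these compounds go, is where a methyl group, a longer alkyl chain or an amine at this place would fall relative to hydrogen and 2-phenylethenyl.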